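Two substituent swaps and their joint effect on growth inhibition

The compounds below may be only part of what the source reports. "The series", "measured", "known", "first", "only" and "open" are said of these compounds alone.

Measured compounds:
Compound 1, `Cc1nn(-c2ccccc2)c(Oc2ccc(-c3nc4cc([N+](=O)[O-])ccc4[nH]3)cc2)c1/C=N/NC(N)=O`: 50 nM in a functional assay on MCF7 cells (Homo sapiens) for cytotoxicity, read by sulforhodamine B assay, with a stated time of 48 h, in the presence of a further agent that is not named here; a higher number here means a weaker inhibitor of growth, a lower number a stronger inhibitor of growth.
Compound 2, `Cc1nn(-c2ccccc2)c(Oc2ccc(-c3nc4cc([N+](=O)[O-])ccc4[nH]3)cc2)c1/C=N/NC(N)=S`: > 100000 nM, a limit.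
Compound 3, `Cc1nn(-c2ccccc2)c(Oc2ccc(-c3nc4cc(C(N)=O)ccc4[nH]3)cc2)c1/C=N/NC(N)=O`: > 100000 nM, a limit.

Among the compounds with values here, compound 1 is the only member of the set with a numerical value in this assay. The change a group of 3 heavy atoms (1 carbon, 1 nitrogen, 1 sulfur; no ring) in place of a group of 3 heavy atoms (1 carbon, 1 nitrogen, 1 oxygen; no ring), on an amine nitrogen produces an at least 2000-fold higher number from compound 1 to compound 2 (3.30 log units; beyond the scatter). The change carbamoyl in place of nitro on an aromatic carbon produces an at least 2000-fold higher number from compound 1 to compound 3 (3.30 log units; beyond the scatter). Both steps end at the limit of > 100000 nM in this assay, at which 2 of the 3 values shown sit, so their true size is not known, only a lower bound.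

Compound 4, `Cc1nn(-c2ccccc2)c(Oc2ccc(-c3nc4cc(C(N)=O)ccc4[nH]3)cc2)c1/C=N/NC(N)=S`, has not been measured in this assay. It differs from compound 3 by a group of 3 heavy atoms (1 carbon, 1 nitrogen, 1 sulfur; no ring) in place of a group of 3 heavy atoms (1 carbon, 1 nitrogen, 1 oxygen; no ring), on an amine nitrogen, the same change as that from compound 1 to compound 2, made at the same place; the cores of the two pairs differ by carbamoyl in place of nitro on an aromatic carbon. Compound 3 already sits at the limit in this assay, and compound 2 shows the sulfur-for-oxygen change ending at the same limit. Compound 4 is therefore expected to stay at or beyond the limit, with an estimated step that the limit leaves unreadable from compound 3 to compound 4. The estimate for compound 4 in this assay is 150000 nM, with a range from 100000 nM to 400000 nM.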

Compound 4, concentration for 50% growth inhibition: > 100000 nM
Compound 4 was reported as a limit; the forecaster's own chance of this, stated with the estimate: 90%; the middle value lies beyond the limit too.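

In this assay compound 4 gives > 100000 nM, which is a limit. No step to compound 4 from compound 3 or compound 2 can be read, because these values all sit at one limit: the limit of > 100000 nM in this assay, at which 3 of the 4 values shown sit.

The compounds shown leave open how far compound 2, compound 3 and compound 4 lie beyond that limit, and whether they differ from one another.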